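Benzyl in place of phenyl on compound 3

A few compounds are considered here, and "the series" means these few. Any claim that something is new, unique, unknown or untested is made for them only; others in the source may bear on it.

Measured so far in an ADME assay on HeLa cells (Homo sapiens) for cytotoxicity, read by XTT assay; a lower number here means that less compound is tolerated, a higher number that more compound is tolerated:
compound 1 `CC(CC1=Cc2ccccc2OC1)c1ccccc1` gives 12500 nM
compound 2 `C1=C(CCCc2ccccc2)COc2ccccc21` gives 200000 nM
compound 3 `c1ccc(CCCCC2COc3ccccc3C2)cc1` gives 100000 nM

Compound 3 at 100000 nM and compound 2 at 200000 nM lie within the scatter of each other. Compound 1 gives 12500 nM and compound 3 gives 100000 nM, and this gap lies outside the scatter, with compound 3 on the higher side.

Compound 4 `c1ccc(CCCCCC2COc3ccccc3C2)cc1` has not yet been measured in this assay and carries one change from compound 3: benzyl in place of phenyl on a saturated chain carbon, four bonds along the chain from a saturated ring carbon with benzyl in place of phenyl on a saturated chain carbon, four bonds along the chain from a saturated ring carbon.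

Among the measured compounds shown here, no measured pair in this set differs in one place only, so no step can be carried over to this change. With compound 3 at 100000 nM as the anchor, the expectation in this assay is no step beyond the scatter, with a slight lean toward a lower number. Compound 1 at 12500 nM shows that a clearly lower number occurs in this small set, so the expected range reaches further down than up. The estimated step runs a 1.3-fold lower number from compound 3 to compound 4 (0.10 log units; within the scatter) and is expected to stay within the scatter. The estimate for compound 4 is 80000 nM with 30000 nM to 200000 nM as its expected range.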

Compound 4, half-maximal cytotoxic concentration: 200000 nM
Beside the measured number, compound 4's estimate is 2.5-fold (0.40 log units) below it; the measured number falls inside the stated range.
By their numbers in this assay, from the lowest: compound 1; then compounds 3, 2 and 4 (each within the scatter of the next).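

In this assay, the replacement of phenyl by benzyl on a saturated chain carbon, four bonds along the chain from a saturated ring carbon, gives the only one-place comparison among the compounds shown: a 2.0-fold higher number from compound 3 to compound 4 (0.30 log units; within the scatter). This position therefore takes benzyl, with 7 heavy atoms against 6 for phenyl, the same aromatic ring of carbon only and no hydrogen-bond donors or acceptors on either group, without a step beyond the scatter. Nothing measured alongside these numbers bears on the result, so the closeness of compound 3 and compound 4 remains a bare observation.

Still open, going by these compounds, is whether an amine or a carboxylic acid in place of benzyl at this position, or a longer chain carrying the same aromatic ring, would give a step beyond the scatter in this assay. Also open is whether the same change from phenyl to benzyl would stay within the scatter on the core of compound 2, where one-place comparisons are still lacking among the compounds shown.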